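Swapping the benzyl arm for a cyclopropylmethyl group

The source may hold more compounds than are shown below. What is called first, only, known or untested is meant among the compounds shown, and "the series" means these compounds.

Measured so far:
compound 1 `Cc1ccc(CSc2nc3nc(C)cc(Nc4cc(-c5ccccc5)[nH]n4)n3n2)cc1` gives 7310 nM
compound 2 `Cc1cc(Nc2cc(-c3ccc(Cl)cc3)[nH]n2)n2nc(SCc3ccc(Br)cc3)nc2n1` gives 4920 nM
compound 3 `Cc1cc(Nc2cc(-c3ccccc3)[nH]n2)n2nc(SCc3ccc(F)cc3)nc2n1` gives 8110 nM

All three compounds were tested in a functional assay on PC-9 cells (Homo sapiens) for inhibition, read by MTT assay, with a stated time of 72 h; a higher number here means a weaker inhibitor, a lower number a stronger inhibitor. Compound 3 has the highest number of the three, but its distance to compound 1 and to compound 2 falls within the scatter, so none of the three can be set apart from the others. Among the measured compounds shown here, the only single-point step among them is a 1.1-fold higher number from compound 1 to compound 3 (0.05 log units; within the scatter), a change of a fluoro in place of a methyl on the benzyl arm that left the number essentially unmoved.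

Compound 4 `Cc1cc(Nc2cc(-c3ccccc3)[nH]n2)n2nc(SCC3CC3)nc2n1` is not yet measured. It differs from compound 3 as follows: cyclopropyl in place of 4-fluorophenyl on a saturated chain carbon bound to a sulfur. For the measured compounds named here, no measured pair shows the loss of a six-membered aromatic ring from this arm; the step from compound 1 to compound 3 only shows that a change at the outer edge of that ring was inconsequential, and compound 2, with a different aromatic ring in the same arm, sits within the scatter of compound 3. Nothing in the data therefore points to a large step. Compound 4 is expected to land near compound 3, with a 1.2-fold higher number from compound 3 to compound 4 (0.09 log units; within the scatter) as the estimated step, the estimate for compound 4 being 10000 nM within 4000 nM to 25000 nM.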

Compound 4, half-maximal inhibitory concentration: > 50000 nM
Compound 4 was reported as a limit; the forecaster's own chance of this, stated with the estimate: 15%; middle value at least 5.0-fold (0.69 log units) from the limit.
By their numbers in this assay, from the lowest: compounds 2, 1 and 3 (each within the scatter of the next). At a limit, above all of these: compound 4.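

In this assay the reading for compound 4 is a limit and not a number: the limit of > 50000 nM in this assay, at which 1 of the 4 values shown sits.

Even as a limit it gives this position a sensitivity that the earlier compounds did not reveal: cyclopropyl in place of 4-fluorophenyl gives an at least 6.1-fold higher number from compound 3 to compound 4 (0.78 log units; beyond the scatter), and cyclopropyl in place of 4-methylphenyl gives an at least 6.8-fold higher number from compound 1 to compound 4 (0.83 log units; beyond the scatter). Among the compounds shown here, until now, the only single-point change on this arm had been at the outer edge of the aromatic ring, and it stayed within the scatter, whereas replacing the whole six-membered aromatic ring does not, so on this saturated chain carbon bound to a sulfur the ring itself matters more than the fluoro or methyl group it carries.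

The compounds shown leave open how far compound 4 lies past its limit, and whether the aromatic ring as such or the larger number of atoms in the arm is what counts, as cyclopropyl changes both at once. A cyclohexyl group on the same carbon would separate those two readings, and a pyridyl ring would test whether a ring of carbon only is needed.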